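The source may hold more compounds than are shown below. What is called first, only, known or untested is meant among the compounds shown, and "the series" means these compounds.

Measured so far in an ADME assay on HT-29 cells (Homo sapiens) for inhibition, read by MTT assay, with a stated time of 72 h; a lower number here means a stronger inhibitor, a higher number a weaker inhibitor:
compound 1, `C=CC(=O)Nc1cccc(Nc2nc(N/N=C(\C)c3ccc(F)cc3F)ncc2Cl)c1`, gives 4360 nM
compound 2, `CN(C)C/C=C/C(=O)Nc1cccc(Nc2nc(N/N=C/c3ccccc3F)ncc2Cl)c1`, gives 3660 nM

Compound 2 has the lowest of the two numbers, but its gap to compound 1 is within the scatter, so the two values only show that both compounds sit close together; neither can be called the stronger on this assay.

Compound 3, `C/C(=N\Nc1ncc(Cl)c(Nc2cccc(NC(=O)/C=C/CN(C)C)c2)n1)c1ccncc1`, is not yet measured. It differs from compound 2 in one place: a group of 9 heavy atoms (7 carbon, 2 nitrogen; one six-membered aromatic ring with 1 hetero atom) in place of a group of 9 heavy atoms (7 carbon, 1 nitrogen, 1 fluorine; one six-membered aromatic ring of carbon only), on a nitrogen on an aromatic ring. The entering group keeps the same size but has a six-membered aromatic ring with 1 hetero atom in place of a ring of carbon only, and carries no fluorine. For the measured compounds named here, no step between measured compounds isolates this change, and compound 1 differs from compound 2 in more than one place, so nothing in the present numbers anchors the direction. The expected step is therefore a 1.2-fold higher number from compound 2 to compound 3 (0.09 log units; within the scatter), a slightly higher number, not beyond the scatter. Compound 3 is estimated at 4500 nM, with a range from 1500 nM to 13000 nM.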

Compound 3, half-maximal inhibitory concentration: 10900 nM
The estimate for compound 3 lay 2.4-fold (0.38 log units) below the measured number; the measured number falls inside the stated range.
By their numbers in this assay, from the lowest: compounds 2 and 1 (each within the scatter of the next); then compound 3.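

In this assay, for the compounds shown here, the group on a nitrogen on an aromatic ring now has a readable step, the only one so far: a 3.0-fold higher number from compound 2 to compound 3 (0.47 log units; beyond the scatter), modest in size but beyond the scatter. The entering and leaving groups both count 9 heavy atoms, so this position responds to a change that leaves the heavy-atom count untouched, and the six-membered aromatic ring with 1 hetero atom, carrying no fluorine, goes with the weaker inhibitor of this pair. Nothing measured here explains the loss of inhibition, as no supporting data bear on it.

The step moves the ring hetero atom and the fluorine together, so the share of each stays unresolved, and a plain phenyl ring at this position would be needed to separate them. Going by these compounds, whether the direction holds for other groups in this place, such as a methoxy-bearing phenyl ring or a ring carrying an amine, and whether it holds with the simple acrylamide of compound 1 in place of the dimethylamino chain, remains open.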